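The source may report more compounds than this note shows. Statements on the series, on what has been measured and on what is new or still open speak of the compounds shown alone.

Compound 1 `O=S(=O)(NCCCCNCc1ccc(Br)cc1)c1cc(C(F)(F)F)cc(C(F)(F)F)c1` gives 2200 nM in a functional assay on PANC-1 cells (Homo sapiens) for inhibition, read by MTT assay, with a stated time of 72 h (on this read-out lower numbers stand for stronger inhibition of growth and higher numbers for weaker inhibition of growth), the lowest of three numbers for compounds sharing one core, though not separated from the others beyond the scatter. Compound 2 `O=S(=O)(NCCCNCC1COc2ccccc2O1)c1cc(C(F)(F)F)cc(C(F)(F)F)c1` gives 3400 nM and compound 3 `O=S(=O)(NCCCNCc1ccc(C(F)(F)F)cc1)c1cc(C(F)(F)F)cc(C(F)(F)F)c1` gives 3200 nM. Among the compounds with values here, the only single-point step measured, a 1.1-fold lower number from compound 2 to compound 3 (0.03 log units; within the scatter), swaps a group on a saturated chain carbon bound to an amine nitrogen and shows no shift beyond the scatter. Compound 4 `CN(CCCNS(=O)(=O)c1cc(C(F)(F)F)cc(C(F)(F)F)c1)Cc1ccccc1` differs from compound 1 by benzyl(methyl)amino in place of ((4-bromobenzyl)amino)methyl on a saturated chain carbon, three bonds along the chain from a sulfonamide nitrogen. Within the data shown here, no measured step matches this change directly, and the one step touching the same region of the chain was flat. Compound 4 is therefore expected to give 3000 nM, within 1200 nM to 8000 nM. That expectation amounts to a 1.4-fold higher number from compound 1 to compound 4 (0.13 log units; within the scatter), a step expected to stay within the scatter.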

Compound 4, concentration for 50% growth inhibition: > 50000 nM
Compound 4 gave a limit, no number; the forecaster's own chance of this, stated with the estimate: 5%; at least 16-fold (1.22 log units) between middle value and limit.
By their numbers in this assay, from the lowest: compounds 1, 3 and 2 (each within the scatter of the next). At a limit, above all of these: compound 4.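

In this assay this place on the chain proves sensitive: benzyl(methyl)amino in place of ((4-bromobenzyl)amino)methyl gives an at least 22-fold higher number from compound 1 to compound 4 (1.35 log units; beyond the scatter), a large loss of growth inhibition that the earlier flat step, a 1.1-fold lower number from compound 2 to compound 3 (0.03 log units; within the scatter), gave no hint of. Compound 4 gives a limit, not a number: the limit of > 50000 nM in this assay, at which 1 of the 4 values shown sits.

From the compounds shown here alone, this single change removes the bromine and a hydrogen-bond donor together, and which of them carries the step stays open. A plain benzylamino group on the same chain would help to separate the two.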